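Swapping a propyl for a cyclopropyl on the pyrimidine

This account rests on a few compounds, and the source may have more. Where it says the series, first, only, none or still open, it means among the compounds named here.

Measured so far:
- compound 1, `CCOc1ncc(-c2nc(C(F)(F)F)sc2N2CCN(C(=O)Cn3nc(C)nc3C)[C@H](C)C2)cn1`: 173 nM
- compound 2, `Cc1ncc(-c2nc(C(F)(F)F)sc2N2CCN(C(=O)Cn3nc(C)nc3C)[C@H](C)C2)cn1`: 578 nM
- compound 3, `CCCc1ncc(-c2nc(C(F)(F)F)sc2N2CCN(C(=O)Cn3nc(C)nc3C)[C@H](C)C2)cn1`: 258 nM

All three compounds share one core and differ only in the group on an aromatic carbon of a six-membered aromatic ring with two nitrogen atoms, sitting between the two ring nitrogen atoms. In a functional assay on U2OS cells for antagonist activity at C-X-C chemokine receptor type 3 (Homo sapiens), read by beta-arrestin recruitment (on this read-out higher numbers stand for weaker inhibition and lower numbers for stronger inhibition), compound 3 holds the second highest of the three numbers; it sits within the scatter of compound 1 and is separated from compound 2 by a modest step, a 2.2-fold lower number from compound 2 to compound 3 (0.35 log units; beyond the scatter). The comparison of compound 1 with compound 3 reads a 1.5-fold higher number from compound 1 to compound 3 (0.17 log units; within the scatter).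

Compound 4, `Cc1nc(C)n(CC(=O)N2CCN(c3sc(C(F)(F)F)nc3-c3cnc(C4CC4)nc3)C[C@H]2C)n1`, has not yet been measured. It differs from compound 3 by cyclopropyl in place of propyl on an aromatic carbon. Within the data shown here, the group that leaves and the group that enters carry the same count of heavy atoms, so the only measured step that bears directly on this change is the growth from compound 2 to compound 3, which lowered the number modestly, while the exchange between compound 1 and compound 3 stayed within the scatter. Nothing measured here distinguishes a chain from a small ring of the same size.

The expectation for compound 4 is therefore a step of a 1.1-fold lower number from compound 3 to compound 4 (0.05 log units; within the scatter), that is, no change beyond the scatter. Compound 4 is estimated at 230 nM, with a range from 100 nM to 520 nM.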

Compound 4, half-maximal inhibitory concentration: 349 nM
Beside the measured number, compound 4's estimate is 1.5-fold (0.18 log units) below it; measured number inside the range.
By their numbers in this assay, from the lowest: compounds 1, 3, 4 and 2 (each within the scatter of the next, the first and the last beyond it).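

In this assay, tying the propyl into a cyclopropyl gives a 1.4-fold higher number from compound 3 to compound 4 (0.13 log units; within the scatter), so at this carbon between the two ring nitrogen atoms, the read-out does not separate an open chain from a three-membered ring with the same count of heavy atoms. Compound 4 also stays within the scatter of the other two groups, with a 1.7-fold lower number from compound 2 to compound 4 (0.22 log units; within the scatter) against the methyl and a 2.0-fold higher number from compound 1 to compound 4 (0.30 log units; within the scatter) against the ethoxy, even though those two groups are themselves separated by a step beyond the scatter, a 3.3-fold higher number from compound 1 to compound 2 (0.52 log units; beyond the scatter); the four compounds therefore form a chain of close neighbours in which only the two ends can be told apart. No measurement shown here accounts for these differences.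

Still open, as far as these compounds go, is what a butyl chain, a cyclobutyl ring or an amine on this same carbon would do to the number in this assay. Also open, from the compounds shown here alone, is whether exchanging propyl for cyclopropyl would leave the number just as close on a different core.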